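The source may report more compounds than this note shows. Statements on the series, on what has been measured and on what is new or still open speak of the compounds shown alone.

Measured compounds:
compound 1 `O=C(Nc1cccc(-n2cc(-c3ccncc3)c(-c3cc(O)cc(Cl)c3)n2)c1)Nc1ccc(Cl)c(C(F)(F)F)c1`: 95%
compound 2 `O=C(Nc1cccc(-n2cc(-c3ccncc3)c(-c3cc(O)cc(Cl)c3)n2)c1)Nc1ccc(Cl)c(Cl)c1`: 85%

In a functional assay on RXF 393 cells (Homo sapiens) for inhibition, read by sulforhodamine B assay, with a stated time of 48 h, tested at 0.1 uM (on this read-out higher numbers stand for a weaker effect at the one concentration tested and lower numbers for a stronger effect), compound 1 gives 95%, the higher of the two numbers shown, which at this single concentration points to only a weak effect. Its nearest neighbour is compound 2, which gives 85%; the step of a number 10 percentage points lower from compound 1 to compound 2 (within the scatter) lies within the scatter, so the two compounds cannot be told apart on these numbers.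

Compound 3 `COc1cc(Cl)cc(-c2nn(-c3cccc(NC(=O)Nc4ccc(Cl)c(C(F)(F)F)c4)c3)cc2-c2ccncc2)c1` has not yet been measured. It differs from compound 1 in one place: methyl in place of hydrogen on an oxygen on an aromatic ring. For the measured compounds named here, no measured step touches this part of the molecule; the only step available, a number 10 percentage points lower from compound 1 to compound 2 (within the scatter), concerns a different group and gives no guide to what the methyl does here. With compound 1 already near the top of the scale, there is little room for a higher number, and nothing in the data points to a large drop either. The step of a number 1 percentage points higher from compound 1 to compound 3 (within the scatter) is therefore expected to be none beyond the scatter. Compound 3 is estimated to give 96%, within a range of 84% to 108%.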

Compound 3, a percentage reported as activity, at one concentration (the size of the read-out at that concentration, not a potency): 96%
Compound 3: the middle estimate sits on the measured number at the digits printed, within the range that was stated.
By their numbers in this assay, from the lowest: compounds 2, 1 and 3 (each within the scatter of the next, the first and the last beyond it).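

In this assay, for the compounds shown here, replacing hydroxy with methoxy on the 3-chloro-5-hydroxyphenyl group gives a number 1 percentage points higher from compound 1 to compound 3 (within the scatter), the first reading at this position, as the earlier step changed a different group. At this single concentration, then, putting a methyl on the oxygen gives no difference that can be told from the scatter, although the free hydroxy hydrogen is gone, and both compounds remain at the weak-effect end of the scale, where a further weakening would be hard to see. No measurement shown here offers an explanation for this result.

On these data alone, it remains open whether a different group at this place, such as an amine, a carboxylic acid or a longer chain on the oxygen like ethoxy, would move the read-out beyond the scatter. As far as these compounds go, it is also open whether compound 1 and compound 3 would stay alike at higher concentrations, where the effect could be stronger than at the one concentration tested.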